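A few compounds are considered here, and "the series" means these few. Any claim that something is new, unique, unknown or untested is made for them only; others in the source may bear on it.

Measured so far:
- compound 1, `CCc1ccc(NC(=O)N[C@H](C)c2ccccc2)cc1`: 44%
- compound 2, `C[C@@H](NC(=O)Nc1ccccc1C(C)(C)C)c1ccccc1`: 17%
- compound 3, `C[C@H](NC(=O)Nc1ccccc1C(C)(C)C)c1ccccc1`: 100%

In an ADME assay on the whole organism with Oryza sativa as the target, tested at 10 uM (on this read-out higher numbers stand for a weaker effect at the one concentration tested and lower numbers for a stronger effect), compound 2 stands lowest of the three numbers, that is, with the strongest effect at the one concentration tested; compound 1 lies above it by a gap beyond the scatter, and compound 3 lies far above it. Within the data shown here, the only measured step is a number 83 percentage points higher from compound 2 to compound 3 (beyond the scatter), which shows the read-out to be very sensitive to configuration at the saturated chain carbon, because of the fact that compounds 2 and 3 differ only in the configuration as drawn.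

Compound 4, `C[C@@H](NC(=O)Nc1ccccc1Cl)c1ccccc1`, keeps the configuration of compound 2 and carries the change (chloro in place of tert-butyl on an aromatic carbon). Among the measured compounds shown here, no measured step touches the group on that aromatic carbon, so the one measured step does not bear on this change and gives no direction for it. The values of compound 1 and compound 2 show that changes at the aniline ring go with a gap beyond the scatter, but that pair differs in more than one place and cannot be read as a step.

The step of a number 23 percentage points higher from compound 2 to compound 4 (beyond the scatter) is therefore an estimate without a measured precedent, and a move away from the low value of compound 2 seems as likely as staying near it. For compound 4 the expected value in this assay is 40%, within 10% to 85%.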

Compound 4, a percentage reported as activity, at one concentration (the size of the read-out at that concentration, not a potency): 93%
Compound 4: the middle estimate sits 53 percentage points below what was measured; the measured number lies above the stated range.
By their numbers in this assay, from the lowest: compound 2; then compound 1; then compounds 4 and 3 (each within the scatter of the next).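

With the configuration held, chloro in place of tert-butyl on an aromatic carbon gives in this assay a number 76 percentage points higher from compound 2 to compound 4 (beyond the scatter), so the group at this place counts for the read-out as well as the configuration does. Read with a number 83 percentage points higher from compound 2 to compound 3 (beyond the scatter), this shows that the low number of compound 2 is lost on changing either of these two features alone, and that keeping the configuration of compound 2 is not enough to retain it. Nothing measured here accounts for the size of the step from tert-butyl to chloro.

On these data alone, whether a methyl, an isopropyl or a methoxy group on this aromatic carbon would keep the low number remains open. Also open, as far as these compounds go, is how chloro at this place would read with the opposite configuration at the saturated chain carbon.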